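The source may report more compounds than this note shows. Statements on the series, on what has been measured and on what is new or still open speak of the compounds shown alone.

In a functional assay on HeLa cells (Homo sapiens) for cytotoxicity, read by WST assay, with a stated time of 48 h (a higher number here means a weaker inhibitor, a lower number a stronger inhibitor), compound 2 `COc1cc(C(c2ccc(O)c(OC)c2)[C@@H](CO)C(C)C)ccc1O` gives > 100000 nM, which is a limit and not a number. It stands at the limit of > 100000 nM in this assay, at which 1 of the 3 values shown sits. Compound 1 `COc1cc(C(c2ccc(O)c(OC)c2)[C@H](C)C(C)C)ccc1O` gives 16000 nM, and compound 3 `COc1cc(C(c2ccc(O)c(OC)c2)[C@H](CC(C)C)C(C)C)ccc1O` gives 8200 nM. Those two differ by a 2.0-fold lower number from compound 1 to compound 3 (0.29 log units; within the scatter), so they offer no ranking.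

Compound 4 `COc1cc(C(c2ccc(O)c(OC)c2)[C@H](C)[C@@H](C)CO)ccc1O` has the same atoms as compound 2, joined differently: 2-(hydroxymethyl)-1-methylpropyl in place of 1-(hydroxymethyl)-2-methylpropyl on a saturated chain carbon bound to two aromatic carbons. A 2-(hydroxymethyl)-1-methylpropyl group takes the place of 1-(hydroxymethyl)-2-methylpropyl on a saturated chain carbon bound to two aromatic carbons.

Going by the values given here, no measured step isolates this kind of rearrangement, so the evidence is indirect. Among the compounds with values here, two steps bear on it, and both involve the side chain of compound 2. One is an at least 6.2-fold higher number from compound 1 to compound 2 (0.79 log units; beyond the scatter), and the other is an at least 12-fold lower number from compound 2 to compound 3 (1.08 log units; beyond the scatter). In both, the side chain carrying hydroxymethyl goes with the higher number, and compound 4 also carries a hydroxymethyl. The expectation is therefore that compound 4 stays near the weak end of this assay, with a small shift towards a lower number at most, or none beyond the scatter. The estimated step is an at least 1.2-fold lower number from compound 2 to compound 4 (0.09 log units; that floor lies within the scatter).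

For compound 4 the expected value is 80000 nM, within an estimated range of 25000 nM to 200000 nM.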

Compound 4, half-maximal inhibitory concentration: > 100000 nM
Compound 4 ended at the assay's limit; the forecaster's own chance of this, stated with the estimate: 55%; middle value at least 1.2-fold (0.09 log units) from the limit.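

In this assay compound 4 gives > 100000 nM, which is a limit of the assay and not a number, so a second hydroxy-bearing chain, 2-(hydroxymethyl)-1-methylpropyl, sits with the 1-(hydroxymethyl)-2-methylpropyl chain of compound 2 at the weak end: the limit of > 100000 nM in this assay, at which 2 of the 4 values shown sit.

The earlier compounds shown here showed the hydroxy group in one arrangement only, whereas this rearranged chain on the saturated chain carbon bound to two aromatic carbons also goes with a higher number, with an at least 6.2-fold higher number from compound 1 to compound 4 (0.79 log units; beyond the scatter) for the added hydroxy and an at least 12-fold higher number from compound 3 to compound 4 (1.08 log units; beyond the scatter) against the larger hydrocarbon chain. The step between compound 2 and compound 4 cannot be read, as both values are limits, so any difference between the two hydroxymethyl chains stays hidden.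

The compounds shown leave open how far past the limit either hydroxy-bearing compound lies, and so whether the placement of the hydroxy matters at all. They also leave open whether the loss follows the hydroxy group specifically or would recur with an amine or a carboxylic acid at the end of the same chain.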